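Swapping an aryl amide for a furan amide on a benzimidazole scaffold

This account rests on a few compounds, and the source may have more. Where it says the series, first, only, none or still open, it means among the compounds named here.

Of the compounds shown here, three share a benzimidazole-based core and have been measured in an assay on isolated protein for inhibition of aldehyde dehydrogenase 1A1 (Homo sapiens), read by spectrophotometry, tested at 10 uM; on this read-out lower numbers stand for less inhibition and higher numbers for more inhibition at the one concentration tested (going by the name of the read-out). Compound 1, `Cc1cccc(Cn2c(CN3CCN(C(=O)c4ccc(C(F)(F)F)cc4)CC3)nc3ccccc32)c1`, carries a 4-(trifluoromethyl)phenyl group on the carbonyl carbon of a piperazine amide, and in this assay compound 1 gives 22.9%. Compound 3, `CCCCn1c(CN2CCN(C(=O)C3CC3)CC2)nc2ccccc21`, gives 18.2% in this assay, a number that cannot be told apart from that of compound 1 within the usual scatter. Compound 2, `Cc1cccc(Cn2c(OC3CCN(C(=O)C4CC4)CC3)nc3ccccc32)c1`, gives 80.6% in this assay, a number that lies well beyond the scatter from compound 1, so compound 1 sits with compound 3 at the low end and far from compound 2.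

Compound 4, `Cc1cccc(Cn2c(CN3CCN(C(=O)c4ccco4)CC3)nc3ccccc32)c1`, differs from compound 1 in one place: furan-2-yl in place of 4-(trifluoromethyl)phenyl on a carbonyl carbon. Within the data shown here, no measured pair here isolates such a swap of the aryl group on the amide carbonyl, so the expectation for compound 4 rests on compound 1 alone. The step from compound 1 to compound 4 is expected to be small, a number 2.1 percentage points higher from compound 1 to compound 4 (within the scatter), with no clear direction beyond the scatter. On this basis compound 4 is estimated at 25% in this assay, within a range from 5% to 55%.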

Compound 4, a percentage reported as inhibition, at one concentration (the size of the read-out at that concentration, not a potency): 73.2%
Compound 4: middle estimate off by 48.2 percentage points, on the low side; the measured number lies above the stated range.
By their numbers in this assay, from the lowest: compounds 3 and 1 (each within the scatter of the next); then compounds 4 and 2 (each within the scatter of the next).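

In this assay, the group on the amide carbonyl turns out to matter a great deal: with the rest of the structure unchanged, furan-2-yl in place of 4-(trifluoromethyl)phenyl gives a number 50.3 percentage points higher from compound 1 to compound 4 (beyond the scatter). Among these compounds, none of the earlier compounds formed a pair differing in one place, so this is the first direct sign that the low number of compound 1 is not fixed by the rest of its structure and that this position alone can move the read-out by a large amount. The swap replaces a six-membered aromatic ring of carbon only with a smaller five-membered aromatic ring that carries a hydrogen-bond acceptor, but nothing available bears on which of these differences, if any, accounts for the step.

This single pair cannot show whether the higher number is particular to furan-2-yl or would also appear with other groups on the carbonyl, such as thiophen-2-yl, pyridin-2-yl or an unsubstituted phenyl. It also leaves open whether a step of this size would hold with other groups elsewhere on the shared core.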